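Exchanging Acetoxy for Dimethylamino on a Shared Core

The source may report more compounds than this note shows. Statements on the series, on what has been measured and on what is new or still open speak of the compounds shown alone.

Compound 1 `O=C1C=CCC/C1=C\C=C\c1ccc(Br)cc1`: 4500 nM
Compound 2 `CC(=O)Oc1ccc(/C=C/C=C2\CCC=CC2=O)cc1`: 4900 nM

Among the compounds with values here, in a functional assay on HGC-27 cells (Homo sapiens) for cytotoxicity, read by MTT assay, with a stated time of 72 h (on this read-out lower numbers stand for stronger inhibition and higher numbers for weaker inhibition), compound 2 gives 4900 nM, the highest of the two numbers measured so far. Within the data shown here, its only neighbour, compound 1, gives 4500 nM in this assay, and the two lie within the scatter, so no order can be read between them. The step of a 1.1-fold higher number from compound 1 to compound 2 (0.04 log units; within the scatter) covers the exchange of bromo for acetoxy on an aromatic carbon and shows no real change in this assay.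

Compound 3 `CN(C)c1ccc(/C=C/C=C2\CCC=CC2=O)cc1` has not yet been measured. It differs from compound 2 in one place: dimethylamino in place of acetoxy on an aromatic carbon. Among the measured compounds shown here, the only measured step that bears on this change is the one just described, which concerns the same aromatic carbon and was flat. Two different groups at this carbon have given nearly equal numbers, so a third exchange there is expected to bring no step beyond the scatter; nothing in the data singles out dimethylamino. Compound 3 is therefore expected to give about 4000 nM in this assay, somewhere between 1500 nM and 10000 nM. The step of a 1.2-fold lower number from compound 2 to compound 3 (0.09 log units; within the scatter) that this estimate implies is expected to stay within the scatter.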

Compound 3, half-maximal inhibitory concentration: 1500 nM
Beside the measured number, compound 3's estimate is 2.7-fold (0.43 log units) above it; low and high end bracket the measured number.
By their numbers in this assay, from the lowest: compound 3; then compounds 1 and 2 (each within the scatter of the next).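

The aromatic carbon that looked indifferent in the earlier pair does respond to the group it carries. In this assay, dimethylamino in place of acetoxy gives a 3.3-fold lower number from compound 2 to compound 3 (0.51 log units; beyond the scatter), and dimethylamino in place of bromo gives a 3.0-fold lower number from compound 1 to compound 3 (0.48 log units; beyond the scatter). Both steps are modest but beyond the scatter, whereas the earlier exchange, a 1.1-fold higher number from compound 1 to compound 2 (0.04 log units; within the scatter), was not, so compound 3 now stands as the most potent of these three compounds, while compound 1 and compound 2 remain indistinguishable. The data offer no measured explanation for why dimethylamino behaves differently from bromo and acetoxy.

With only three groups at this one carbon, the compounds shown cannot tell whether the lower number belongs to dimethylamino alone or would also appear with other nitrogen groups, such as a plain amine, diethylamino or a pyrrolidine ring, or with an oxygen group such as methoxy. They also leave open whether dimethylamino would give a similar step on another carbon of the aromatic ring or with changes elsewhere in the shared core.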